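Extending the Sulfonate Cap from Methyl to Ethyl

The source may hold more compounds than are shown below. What is called first, only, known or untested is meant among the compounds shown, and "the series" means these compounds.

Compound 1, `O=S(=O)(O)c1ccc(F)c2ncc(I)cc12`: in an assay for inhibition of methylcytosine dioxygenase TET2 (Homo sapiens), read by mass spectrometry, with stated times of 30 min and 1 h (on this read-out lower numbers stand for stronger inhibition and higher numbers for weaker inhibition), compound 1 gives 2300 nM.
Compound 2, `COS(=O)(=O)c1ccc(F)c2ncc(I)cc12`: in this assay compound 2 gives > 200000 nM, which is a limit of the assay and not a number.

Compound 2 therefore stands at the limit of > 200000 nM in this assay, at which 1 of the 2 values shown sits, with only a limit known. Among the compounds with values here, the single measured step, an at least 86-fold higher number from compound 1 to compound 2 (1.93 log units; beyond the scatter), came from placing methyl on the sulfonate oxygen. Compound 3, `CCOS(=O)(=O)c1ccc(F)c2ncc(I)cc12`, differs from compound 2 by methyl in place of hydrogen on a saturated chain carbon bound to an oxygen on an unsaturated carbon. That measured step shows inhibition already lost once the oxygen is capped, so lengthening the cap gives no reason to expect a change beyond the scatter. In this assay compound 3 is expected to give 250000 nM (range 80000 nM to 800000 nM), an expected step that the limit leaves unreadable from compound 2 to compound 3, most likely reported again as a limit.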

Compound 3, half-maximal inhibitory concentration: > 200000 nM
Compound 3: a limit, no number; the forecaster's own chance of this, stated with the estimate: 85%; the middle value does not contradict the limit.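

Lengthening the cap on the sulfonate oxygen from methyl to ethyl brings no measurable inhibition back in this assay, so the loss is not confined to the methoxysulfonyl group. Set against the uncapped compound, the ethoxysulfonyl group gives an at least 86-fold higher number from compound 1 to compound 3 (1.93 log units; beyond the scatter). Compound 2 and compound 3 both end at a limit of the assay, and the step between them cannot be read: the limit of > 200000 nM in this assay, at which 2 of the 3 values shown sit.

On these data alone, it remains open how far compound 2 and compound 3 lie past that limit, and whether a sulfonamide or a carboxylic acid in place of the sulfonate would keep inhibition.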